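Three limits and a methoxy in place of amino

A few compounds are considered here, and "the series" means these few. Any claim that something is new, unique, unknown or untested is made for them only; others in the source may bear on it.

- compound 1 `Nc1nc(N)c2c(-c3ccco3)cn([C@@H]3O[C@H](CO)[C@@H](O)[C@H]3O)c2n1`: > 20000 nM
- compound 2 `Nc1nc(N)c2c(-c3cccs3)cn([C@@H]3O[C@H](CO)[C@@H](O)[C@H]3O)c2n1`: > 20000 nM
- compound 3 `Cc1nc(N)c2c(-c3ccco3)cn([C@@H]3O[C@H](CO)[C@@H](O)[C@H]3O)c2n1`: > 20000 nM

All three entries are limits and not numbers. In a functional assay on HCT-116 cells (Homo sapiens), read by MTT assay, with a stated time of 72 h (a lower number here means a stronger inhibitor, a higher number a weaker inhibitor), compound 1 stands at the limit of > 20000 nM in this assay, at which 3 of the 3 values shown sit.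

The next compound, compound 4 `COc1nc(N)nc2c1c(-c1ccco1)cn2[C@@H]1O[C@H](CO)[C@@H](O)[C@H]1O`, carries methoxy in place of amino on an aromatic carbon of the core of compound 1: methoxy in place of amino on an aromatic carbon.

Two measured steps start from compound 1, and neither gives a size. Thiophen-2-yl in place of furan-2-yl gives a step that the two limits leave unreadable from compound 1 to compound 2. Methyl in place of amino, at a different amino group from the one lost in compound 4, gives a step that the two limits leave unreadable from compound 1 to compound 3. The second step is the closer guide, yet it fixes neither a size nor a direction. No step beyond the scatter is therefore expected in this assay, and compound 4 will most likely also be reported only as a limit. The expected change is a number no higher from compound 1 to compound 4 (the limit leaves the size open). For compound 4 the estimate is 20000 nM, with an expected range from 7000 nM to 40000 nM.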

Compound 4, half-maximal inhibitory concentration: > 20000 nM
Compound 4: no number, only a limit; the forecaster's own chance of this, stated with the estimate: 75%; the middle value lies on the limit itself.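

In this assay compound 4 gives > 20000 nM as a limit and not a number. Going by these compounds alone, compound 1 is also a limit, so no step between compound 1 and compound 4 can be read. The compounds shown leave open how strongly any of them inhibits, and whether any of these changes alters that: the limit of > 20000 nM in this assay, at which 4 of the 4 values shown sit.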